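Cytotoxicity of anilinopyrimidines: a halogenated benzyl ether variant

The source may report more compounds than this note shows. Statements on the series, on what has been measured and on what is new or still open speak of the compounds shown alone.

Measured compounds:
Compound 1 `CN(C)c1ccnc(Nc2ccc(C#N)cc2)n1` in an ADME assay on MT4 cells (Homo sapiens) for cytotoxicity, read by MTT assay, with a stated time of 5 days (on this read-out higher numbers stand for lower toxicity in this test and lower numbers for higher toxicity in this test), gives 34000 nM
Compound 2 `N#Cc1ccc(Nc2nccc(OCc3ccc(Cl)cc3)n2)cc1` in this assay gives 156000 nM
Compound 3 `COc1cc(COc2ccnc(Nc3ccc(C#N)cc3)n2)cc(OC)c1` in this assay gives 44200 nM

Of the three measured compounds, compound 2 stands highest in this assay, meaning it is the least toxic of the three on this read-out. The nearest of the others is compound 3, whose number is lower by a margin beyond the usual scatter, and the furthest is compound 1, lower still. No pair of these compounds differs in only one place, so no single structural step can be drawn among them.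

Compound 4 `N#Cc1ccc(Nc2nccc(OCc3ccc(Br)cc3F)n2)cc1` is not yet measured. It differs from compound 2 as follows: 4-bromo-2-fluorophenyl in place of 4-chlorophenyl on a saturated chain carbon bound to an oxygen on an aromatic ring. Both the leaving and the entering groups carry no donors or acceptors and bear no charge, and the core is untouched. The step from compound 2 to compound 4 is therefore expected to be small, and a value close to that of compound 2 is expected for compound 4, a 1.3-fold lower number from compound 2 to compound 4 (0.11 log units; within the scatter), with no direction claimed beyond the scatter. The estimate for compound 4 in this assay is 120000 nM, ranging from 50000 nM to 250000 nM.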

Compound 4, half-maximal cytotoxic concentration: 141000 nM
Compound 4: middle estimate off by 1.2-fold (0.07 log units), on the low side; low and high end bracket the measured number.
By their numbers in this assay, from the lowest: compounds 1 and 3 (each within the scatter of the next); then compounds 4 and 2 (each within the scatter of the next).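

In this assay, placing 4-bromo-2-fluorophenyl where compound 2 carries 4-chlorophenyl gives a 1.1-fold lower number from compound 2 to compound 4 (0.04 log units; within the scatter) on this read-out. This is the only step shown at this position, on a saturated chain carbon bound to an oxygen on an aromatic ring, and it shows that a fluorine and a bromine on the phenyl ring in place of a chlorine leave the two compounds indistinguishable in this test. No measurement is available that would account for this result.

As far as these compounds go, the fluorine and the bromine enter in a single step, so their separate shares remain unknown. Also open, from the compounds shown here alone, is how this position would respond to an amine or a carboxylic acid on the phenyl ring, or to a longer chain at the saturated carbon.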